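This account rests on a few compounds, and the source may have more. Where it says the series, first, only, none or still open, it means among the compounds named here.

Compound 3 `CCOC(=O)c1nc(NC(=O)c2ccc(F)cc2)nc2nn(C)cc12` gives only a limit in a functional assay on CHO cells for antagonist activity at adenosine receptor A2b (Homo sapiens); a lower number here means a stronger inhibitor, a higher number a weaker inhibitor: for compound 3 the reading is > 20000 nM, a limit of the assay rather than a number. Compound 1 `CC(C)n1cc2c(C(N)=O)nc(N)nc2n1` likewise stops at a limit, > 20000 nM. Compound 2 `CCOC(=O)c1nc(N)nc2nn(CC(C)(C)C)cc12` also stands at a limit, > 15000 nM. None of the three compounds thus reaches a measured number, and compound 3 shares the limit of > 20000 nM in this assay, at which 2 of the 3 values shown sit, with compound 1. The unmeasured compound 4 `CCOC(=O)c1nc(NC(=O)c2ccc(C)cc2)nc2nn(C)cc12` is made from compound 3 by methyl in place of fluoro on an aromatic carbon. Among the measured compounds shown here, no step between measured compounds is available, so the expectation rests on the change alone. Compound 4 is expected to shift by a step that the limit leaves unreadable from compound 3 to compound 4 in this assay, within the scatter and in no clear direction. Compound 4 is therefore estimated at 30000 nM, between 8000 nM and 100000 nM, most likely again reported as a limit.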

Compound 4, inhibition constant: > 20000 nM
Compound 4: only a limit was reported (the forecaster's own chance of this, stated with the estimate: 85%); the middle value lies beyond the limit too.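

Compound 3 and compound 4 both stop at a limit in this assay, so the step between fluoro and methyl cannot be read. The compounds shown leave open which change to the shared core, if any, would bring a numerical reading in this assay.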